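Thiocarbamate chromenones: antiproliferative activity on LM7 cells

The source may hold more compounds than are shown below. What is called first, only, known or untested is meant among the compounds shown, and "the series" means these compounds.

Measured compounds:
- compound 1, `CCOC(=O)c1cc(=O)c2cc(CSC(=S)N(C)c3ccccc3)ccc2o1`: > 25000 nM
- compound 2, `COc1ccc2occ(CSC(=S)N3CCCC3)c(=O)c2c1`: 6000 nM

The series was read in a functional assay on LM7 cells (Homo sapiens) for antiproliferative activity, read by MTT assay, with a stated time of 72 h; on this read-out higher numbers stand for weaker inhibition and lower numbers for stronger inhibition. Compound 1 reaches only a limit of the assay, > 25000 nM, and no number is known for it; this is the limit of > 25000 nM in this assay, at which 1 of the 2 values shown sits. Compound 2 gives 6000 nM in this assay. For the measured compounds named here, no step between measured compounds that differ in one place is available, so the two values stand side by side without a connection that could be drawn.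

The step of interest leads from compound 1 to compound 3, `CCOC(=O)c1cc(=O)c2cc(CSC(=S)N(C(C)C)C(C)C)ccc2o1`. The change is diisopropylamino in place of methyl(phenyl)amino on a thiocarbonyl carbon. With compound 1 sitting at a limit, only the direction can be weighed. The step from compound 1 to compound 3 is expected to be small and not beyond the scatter, a step that the limit leaves unreadable from compound 1 to compound 3. Compound 3 is therefore expected to give 30000 nM in this assay, with a range from 8000 nM to 100000 nM, and a limit rather than a number is the more likely outcome.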

Compound 3, half-maximal inhibitory concentration: > 25000 nM
Compound 3 ended at the assay's limit; the forecaster's own chance of this, stated with the estimate: 65%; the middle value is on the limit's open side.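

Compound 3 gives > 25000 nM as a limit and not a number. With compound 1 at a limit as well, no step can be read between compound 1 and compound 3: the limit of > 25000 nM in this assay, at which 2 of the 3 values shown sit. The compounds shown leave open how diisopropylamino and methyl(phenyl)amino on a thiocarbonyl carbon compare.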